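From oxolan-3-yl to 1-methylpiperidin-4-yl on an aromatic nitrogen

The source may report more compounds than this note shows. Statements on the series, on what has been measured and on what is new or still open speak of the compounds shown alone.

In a functional assay on KG-1 cells (Homo sapiens) for antiproliferative activity, read by CCK-8 assay, with a stated time of 72 h (on this read-out higher numbers stand for weaker inhibition and lower numbers for stronger inhibition), compound 1 `CCCn1cc(-c2n[nH]c3cc(-c4cc(C(=O)Nc5cccc(C(F)(F)F)c5)ccc4C)ccc23)cn1` gives 358 nM and compound 2 `Cc1ccc(C(=O)Nc2cccc(C(F)(F)F)c2)cc1-c1ccc2c(-c3cnn(C4CCOC4)c3)n[nH]c2c1` gives 304 nM so the two stand level within the scatter. Compound 3 `Cc1ccc(C(=O)Nc2cccc(C(F)(F)F)c2)cc1-c1ccc2c(-c3cnn(C4CCN(C)CC4)c3)n[nH]c2c1` carries 1-methylpiperidin-4-yl in place of oxolan-3-yl on an aromatic nitrogen. For the measured compounds named here, the only measured step at this place (a 1.2-fold lower number from compound 1 to compound 2 (0.07 log units; within the scatter)) put oxolan-3-yl in place of propyl and stayed within the scatter, so no step beyond the scatter is expected, although a single step is thin evidence. The estimated step in this assay is a 1.2-fold lower number from compound 2 to compound 3 (0.08 log units; within the scatter) and is expected to stay within the scatter. For compound 3 the estimated value is 250 nM (expected range 90 nM to 700 nM).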

Compound 3, half-maximal inhibitory concentration: 93.3 nM
Beside the measured number, compound 3's estimate is 2.7-fold (0.43 log units) above it; measured number inside the range.
By their numbers in this assay, from the lowest: compound 3; then compounds 2 and 1 (each within the scatter of the next).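

In this assay, the position on the aromatic nitrogen now proves able to shift the number: the change gives a 3.3-fold lower number from compound 2 to compound 3 (0.51 log units; beyond the scatter), and measured against propyl it gives a 3.8-fold lower number from compound 1 to compound 3 (0.58 log units; beyond the scatter), whereas propyl and oxolan-3-yl had stood level. Among the three groups shown, only 1-methylpiperidin-4-yl, the one with a ring nitrogen, stands apart. Nothing available gives a reason for this step.

Open, as far as these compounds go, is whether the ring nitrogen matters or the six-membered ring alone: cyclohexyl would test the ring without nitrogen, and an open-chain amine such as 2-(dimethylamino)ethyl would test the amine without the ring.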